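The source may hold more compounds than are shown below. What is called first, only, known or untested is meant among the compounds shown, and "the series" means these compounds.

Measured compounds:
Compound 1, `CCOC(=O)c1oc2ccc(N(Cc3ccccc3)S(=O)(=O)c3ccc(Cl)cc3)cc2c1C`: in a functional assay on HCT-116 cells (Homo sapiens) for inhibition, read by MTT assay, with a stated time of 72 h (a lower number here means a stronger inhibitor, a higher number a weaker inhibitor), compound 1 gives 4860 nM.
Compound 2, `Cc1c(C(=O)O)oc2ccc(N(Cc3ccccc3)S(=O)(=O)c3ccc(Cl)cc3)cc12`: in this assay compound 2 gives 9130 nM.

Going by the values given here, compound 2 has the highest of the two numbers so far, and its only neighbour is compound 1, from which it is separated by a 1.9-fold higher number from compound 1 to compound 2 (0.27 log units; within the scatter), a gap that does not rise above the scatter of the assay. The step to compound 3, `Cc1c(C(=O)NCCCn2ccnc2)oc2ccc(N(Cc3ccccc3)S(=O)(=O)c3ccc(Cl)cc3)cc12`, introduces ((3-(1H-imidazol-1-yl)propyl)amino in place of hydroxy on a carbonyl carbon). Among the compounds with values here, the single measured step, hydrogen in place of ethyl on the oxygen of the carbonyl group, touches the same carbonyl position and was small, so it is the only comparison that speaks to this change, and it suggests that alterations at this carbonyl have so far moved the number little. Within the data shown here, no measured compound carries an amide at this position, so the direction for compound 3 rests on that one small step alone. Compound 3 is therefore expected to give about 4500 nM in this assay, within a range of 1200 nM to 16000 nM. The step implied for compound 3 is an expected 2.0-fold lower number from compound 2 to compound 3 (0.31 log units; beyond the scatter), not clearly beyond the scatter.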

Compound 3, half-maximal inhibitory concentration: 17100 nM
Estimate against measurement, compound 3: 3.8-fold (0.58 log units) below, outside the stated range (above it).
By their numbers in this assay, from the lowest: compounds 1, 2 and 3 (each within the scatter of the next, the first and the last beyond it).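

In this assay, going by these compounds alone, the carbonyl carbon carries an amide for the first time, and putting (3-(1H-imidazol-1-yl)propyl)amino in place of hydroxy gives a 1.9-fold higher number from compound 2 to compound 3 (0.27 log units; within the scatter), so the amide and the acid are not told apart. Set against ethoxy on the same carbon, the same group gives a 3.5-fold higher number from compound 1 to compound 3 (0.55 log units; beyond the scatter), the first step at this position that rises beyond the scatter, though only modestly, and it shows that a change here can raise the number even if no group shown lowers it beyond the scatter. No measurement available here accounts for this difference.

As far as these compounds go, whether the amide link or the five-membered aromatic ring sets the value of compound 3 stays open, and a methylamino group on the same carbonyl carbon, or a longer chain ending in the same ring, would help to separate the two. From the compounds shown here alone, the rest of the core is the same in all three compounds, so it is also open whether the gap between ethoxy and the new group would persist with a different group elsewhere on the molecule.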